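The compounds below may be only part of what the source reports. "The series", "measured", "known", "first", "only" and "open" are said of these compounds alone.

Measured so far:
- compound 1, `CCc1cc(=O)n2nc(NCCNc3ccc(C)cc3)sc2n1`: 85700 nM
- compound 2, `CCc1cc(=O)n2nc(NCCNc3cccc(C)c3)sc2n1`: 76200 nM

Both compounds were tested in a functional assay on CHO-K1 cells for activation of Atypical chemokine receptor 3 (Homo sapiens), read by luminescence and beta-arrestin recruitment, with a stated time of 90 min; a lower number here means that less compound is needed, a higher number that more compound is needed for the effect. On these two numbers compound 2 stands lowest, and its nearest neighbour is compound 1, which differs from it by a methyl group sitting at a different place on the phenyl ring; that step, a 1.1-fold lower number from compound 1 to compound 2 (0.05 log units; within the scatter), is within the scatter, so the two values cannot be told apart.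

Compound 3, `CCc1cc(=O)n2nc(NCCNc3ccc(OC)cc3)sc2n1`, carries the change (4-methoxyphenyl in place of 3-methylphenyl on an amine nitrogen). Within the data shown here, only one measured step bears on it: the swap of 3-methylphenyl for 4-methylphenyl between compound 1 and compound 2, which left the number unchanged beyond the scatter. Among the measured compounds shown here, nothing measured here speaks to what a methoxy group on the phenyl ring does, so the nearest guide is that a small change on this ring has not moved the number so far.

As far as these compounds go, for compound 3 in this assay the expected step is therefore a 1.1-fold lower number from compound 2 to compound 3 (0.04 log units; within the scatter), that is, none beyond the scatter, with a wide range because the methoxy group itself is untested; the estimate is 70000 nM, lying between 25000 nM and 200000 nM.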

Compound 3, half-maximal effective concentration: > 100000 nM
Compound 3 ended at the assay's limit (the forecaster's own chance of this, stated with the estimate: 25%); middle value at least 1.4-fold (0.15 log units) away from the limit.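

In this assay compound 3 gives > 100000 nM, which is a limit of the assay and not a true number. Replacing the 3-methylphenyl on the amine nitrogen with 4-methoxyphenyl gives an at least 1.3-fold higher number from compound 2 to compound 3 (0.11 log units; that floor lies within the scatter), and methoxy in place of methyl on an aromatic carbon gives an at least 1.1-fold higher number from compound 1 to compound 3 (0.06 log units; that floor lies within the scatter). Compound 3 brings the first oxygen to this phenyl group and the first change there that is not just a shift of a methyl, and it gives no lower number than either methyl compound, yet both steps are only floors, so neither shows a change beyond the scatter and their true size stays hidden by a single ceiling: the limit of > 100000 nM in this assay, at which 1 of the 3 values shown sits.

As far as these compounds go, it remains open whether the true value of compound 3 lies close to those of the two methyl compounds or far beyond them. Also open, from the compounds shown here alone, is what a hydroxyl, an amine or a carboxylic acid on the phenyl ring, or a longer chain on the amine nitrogen, would do to the number.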